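The compounds below may be only part of what the source reports. "The series", "measured", "known", "first", "only" and "open" are said of these compounds alone.

Measured so far:
Compound 1 `COc1cccc(C(C)Sc2nc3c(cnn3C)c(=O)n2-c2ccccc2)c1` gives 174 nM in an assay on isolated protein for inhibition of Retinaldehyde dehydrogenase 3 (Homo sapiens); on this read-out higher numbers stand for weaker inhibition and lower numbers for stronger inhibition.
Compound 2 `C#Cc1ccc(-n2c(SC(C)c3ccccc3)nc3c(cnn3C)c2=O)cc1` gives 520 nM in this assay.
Compound 3 `CC(Sc1nc2c(cnn2C)c(=O)n1-c1ccccc1)c1ccccc1` gives 73 nM in this assay.

Compound 3 holds the lowest number of the three: a 2.4-fold lower number from compound 1 to compound 3 (0.38 log units; beyond the scatter) and a 7.1-fold lower number from compound 2 to compound 3 (0.85 log units; beyond the scatter), each beyond the scatter. Compound 4 `CC(Sc1nc2c(cnn2C)c(=O)n1-c1ccccc1)c1cccnc1` differs from compound 3 by pyridin-3-yl in place of phenyl on a saturated chain carbon bound to a saturated chain carbon and a sulfur. Neither measured step is the same kind of change; both replace a group on an aromatic carbon with hydrogen rather than exchanging one ring for another, so they serve only as a loose guide that changes around the aromatic rings have given modest steps. A step of similar size is therefore expected, probably toward a higher number. Compound 4 is expected to give 130 nM, within 45 nM to 380 nM, which means a 1.8-fold higher number from compound 3 to compound 4 (0.25 log units; within the scatter).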

Compound 4, half-maximal inhibitory concentration: 95 nM
Estimate against measurement, compound 4: 1.4-fold (0.14 log units) above; low and high end bracket the measured number.
By their numbers in this assay, from the lowest: compounds 3, 4 and 1 (each within the scatter of the next, the first and the last beyond it); then compound 2.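

In this assay, within the data shown here, this is the first exchange of the whole ring on the saturated chain carbon bound to a saturated chain carbon and a sulfur, and putting a ring nitrogen into it gives a 1.3-fold higher number from compound 3 to compound 4 (0.11 log units; within the scatter). Pyridin-3-yl in place of 3-methoxyphenyl likewise gives a 1.8-fold lower number from compound 1 to compound 4 (0.26 log units; within the scatter), so at this place the number stays within the scatter for both exchanges. No measurement here explains why.

The compounds shown leave open how pyridin-2-yl, pyridin-4-yl or a saturated piperidine ring would read at this place.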